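Swapping the para substituent on the pendant aryl ring

A few compounds are considered here, and "the series" means these few. Any claim that something is new, unique, unknown or untested is made for them only; others in the source may bear on it.

Compound 2 `COc1ccc(CN2C(=O)C(=O)c3cc(-c4ccc(C(F)(F)F)cc4)ccc32)cc1` is the stronger of the two measured compounds: in a functional assay on HepG2 cells (Homo sapiens) for antiproliferative activity, read by MTT assay, with a stated time of 48 h (a higher number here means a weaker inhibitor, a lower number a stronger inhibitor), compound 2 gives 820 nM, while compound 1 `COc1ccc(CN2C(=O)C(=O)c3cc(-c4ccc(C(C)(C)C)cc4)ccc32)cc1` gives 4580 nM, and the step of a 5.6-fold lower number from compound 1 to compound 2 (0.75 log units; beyond the scatter) lies beyond the scatter. Compound 3 `COc1ccc(CN2C(=O)C(=O)c3cc(-c4ccc(O)cc4)ccc32)cc1` has not yet been measured. It differs from compound 2 by hydroxy in place of trifluoromethyl on an aromatic carbon; the hydroxy sits on an aromatic carbon of a six-membered aromatic ring of carbon only, para to a large group, the same place that carried tert-butyl in compound 1 and trifluoromethyl in compound 2. Within the data shown here, the only step that bears on this position is a 5.6-fold lower number from compound 1 to compound 2 (0.75 log units; beyond the scatter), which shows that the group here can move the number well beyond the scatter; no measured compound carries a hydroxy or any group bearing a hydrogen-bond donor here, so the direction for compound 3 cannot be read from a matching precedent. A step of the size a 3.7-fold higher number from compound 2 to compound 3 (0.56 log units; beyond the scatter) is therefore expected, with wide uncertainty. For compound 3 the estimate in this assay is 3000 nM, within a range from 700 nM to 13000 nM.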

Compound 3, half-maximal inhibitory concentration: > 10000 nM
Compound 3 was reported as a limit (the forecaster's own chance of this, stated with the estimate: 15%); at least 3.3-fold (0.52 log units) between middle value and limit.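

In this assay compound 3 gives > 10000 nM, which is a limit of the assay and not a number. The earlier compounds shown here showed only that this position can move the number, and only between tert-butyl and trifluoromethyl; hydroxy now adds a group carrying a hydrogen-bond donor, and it gives a higher number than either of them, with an at least 12-fold higher number from compound 2 to compound 3 (1.08 log units; beyond the scatter) and an at least 2.1-fold higher number from compound 1 to compound 3 (0.33 log units; beyond the scatter). So the change from 4-(trifluoromethyl)phenyl to 4-hydroxyphenyl costs more than the earlier exchange at this place, a 5.6-fold lower number from compound 1 to compound 2 (0.75 log units; beyond the scatter), and the true size of both new steps remains unknown, as each rests on a single reading for compound 3: the limit of > 10000 nM in this assay, at which 1 of the 3 values shown sits.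

The compounds shown leave open whether the loss goes with the hydroxy hydrogen or with the oxygen, a question that methoxy or an amine at this place would bear on. They also leave open whether a nitrile or a chlorine here would stay near compound 2 or fall away as compound 3 does.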